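The compounds below may be only part of what the source reports. "The series", "measured", "known", "first", "only" and "open" are said of these compounds alone.

Measured so far:
- compound 1, `O=C1CC(O)CC(CSc2nc(-c3ccccc3)c(-c3ccccc3)[nH]2)O1`: 910 nM
- compound 2, `CC1(C)CC(=O)OC(CSc2nc(-c3ccccc3)c(-c3ccccc3)[nH]2)C1`: 100 nM

In an assay on microsomes from liver for inhibition of sterol O-acyltransferase 1 (Rattus norvegicus) (on this read-out higher numbers stand for weaker inhibition and lower numbers for stronger inhibition), compound 2 stands lowest of the two, with compound 1 giving the higher number. Within the data shown here, the only measured step, a 9.1-fold lower number from compound 1 to compound 2 (0.96 log units; beyond the scatter), changed the same six-membered ring that is now replaced altogether. Compound 3, `c1ccc(-c2nc(SCC3OCCO3)[nH]c2-c2ccccc2)cc1`, differs from compound 2 by a group of 5 heavy atoms (3 carbon, 2 oxygen; one five-membered non-aromatic ring with 2 hetero atoms) in place of a group of 9 heavy atoms (7 carbon, 2 oxygen; one six-membered non-aromatic ring with 1 hetero atom), on a saturated chain carbon bound to a sulfur. Among the measured compounds shown here, no measured step covers this exchange, so the direction is uncertain; because the ring proved sensitive in a 9.1-fold lower number from compound 1 to compound 2 (0.96 log units; beyond the scatter), a weaker result is expected for compound 3, estimated at 500 nM (range 100 nM to 3000 nM), a step of a 5.0-fold higher number from compound 2 to compound 3 (0.70 log units; beyond the scatter).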

Compound 3, half-maximal inhibitory concentration: 530 nM
Compound 3: the middle estimate sits 1.1-fold (0.03 log units) below what was measured; low and high end bracket the measured number.
By their numbers in this assay, from the lowest: compound 2; then compounds 3 and 1 (each within the scatter of the next).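

In this assay the exchange of the six-membered ring for 1,3-dioxolan-2-yl gives a 5.3-fold higher number from compound 2 to compound 3 (0.72 log units; beyond the scatter) and so gives up the advantage of compound 2. The same group in place of the ring of compound 1 gives a 1.7-fold lower number from compound 1 to compound 3 (0.23 log units; within the scatter) and thus no readable difference, so among these three groups on a saturated chain carbon bound to a sulfur, only the ring of compound 2 stands apart. Nothing measured here says why that ring differs. As far as these compounds go, whether an open butyl chain or an amine at this place would do as well as the ring of compound 2 stays open.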